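The source may hold more compounds than are shown below. What is called first, only, known or untested is meant among the compounds shown, and "the series" means these compounds.

In a functional assay on HCT-15 cells (Homo sapiens) for inhibition, read by sulforhodamine B assay, with a stated time of 48 h, tested at 1 uM (a higher number here means a weaker effect of the compound at the concentration tested, a lower number a stronger effect), compound 2 `O=C(Nc1cccc(-n2cc(-c3ccncc3)c(-c3cc(O)cc(Cl)c3)n2)c1)Nc1ccc(Cl)c(Cl)c1` gives 75%, the second highest of the three numbers: compound 1 `O=C(Nc1cccc(-n2cc(-c3ccncc3)c(-c3cc(O)cc(Cl)c3)n2)c1)Nc1ccc(Cl)c(C(F)(F)F)c1` gives 90%, and compound 3 `COc1cc(Cl)cc(-c2nn(-c3cccc(NC(=O)Nc4cc(C(F)(F)F)cc(C(F)(F)F)c4)c3)cc2-c2ccncc2)c1` gives 17%. For the measured compounds named here, the only step measured in one place, a number 15 percentage points lower from compound 1 to compound 2 (beyond the scatter), concerns chloro in place of trifluoromethyl, not the oxygen at hand. Compound 4 `COc1cc(Cl)cc(-c2nn(-c3cccc(NC(=O)Nc4ccc(Cl)c(Cl)c4)c3)cc2-c2ccncc2)c1` differs from compound 2 by methyl in place of hydrogen on an oxygen on an aromatic ring. Going by the values given here, no measured step isolates this change; compound 3 carries the methoxy but also differs elsewhere, so its gap to compound 2 mixes two changes. The step to compound 4 is therefore expected to be a number 20 percentage points lower from compound 2 to compound 4 (beyond the scatter), a lowering of uncertain size, leaning on compound 3 at 17%. Compound 4 is estimated at 55%, between 25% and 85%.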

Compound 4, a percentage reported as activity, at one concentration (the size of the read-out at that concentration, not a potency): 77%
Compound 4: middle estimate off by 22 percentage points, on the low side, within the range that was stated.
By their numbers in this assay, from the lowest: compound 3; then compounds 2 and 4 (each within the scatter of the next); then compound 1.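

In this assay, the change from hydroxy to methoxy reads as a number 2 percentage points higher from compound 2 to compound 4 (within the scatter), so with the rest of compound 2 held, the hydroxy hydrogen makes no visible difference at this position. Among the two methoxy compounds, compound 4 gives 77% and compound 3 gives 17%, so the methoxy alone does not go with the low number of compound 3. Nothing on hand explains this flat step. Open, going by these compounds, is whether an amine or an ethoxy at this position would also leave the number unmoved. Also open, on these data alone, is whether hydroxy to methoxy reads the same with the trifluoromethyl-bearing ring of compound 1.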